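The source may hold more compounds than are shown below. What is called first, only, known or untested is meant among the compounds shown, and "the series" means these compounds.

In an ADME assay on BJ cells (Homo sapiens) for antiproliferative activity, with a stated time of 72 h (a higher number here means that more compound is needed for the effect, a lower number that less compound is needed), compound 3 `COc1ccc(-c2cc(=O)c3c(OC)cc(OC)cc3n2S(=O)(=O)c2cc(F)c(F)c(F)c2)cc1` gives only a limit, > 65500 nM. Compound 1 `COc1ccc(-c2cc(=O)c3c(OC)cc(OC)cc3n2S(=O)(=O)c2ccc([N+](=O)[O-])cc2)cc1` likewise gives a limit, > 29300 nM. Compound 2 `COc1ccc(-c2cc(=O)c3c(OC)cc(OC)cc3n2S(=O)(=O)c2ccc(C#N)cc2)cc1` also gives a limit, > 17200 nM. The measured steps a step that the two limits leave unreadable from compound 1 to compound 2, a step that the two limits leave unreadable from compound 1 to compound 3 and a step that the two limits leave unreadable from compound 2 to compound 3 cannot be sized, because every value sits at a limit: the limit of > 17200 nM in this assay, at which 1 of the 3 values shown sits, the limit of > 29300 nM in this assay, at which 1 of the 3 values shown sits, and (the limit of > 65500 nM in this assay, at which 1 of the 3 values shown sits). Compound 4 `COc1ccc(-c2cc(=O)c3c(OC)cc(OC)cc3n2S(=O)(=O)c2c(F)c(F)c(F)c(F)c2F)cc1` differs from compound 3 by 2,3,4,5,6-pentafluorophenyl in place of 3,4,5-trifluorophenyl on a sulfonyl sulfur. For the measured compounds named here, all three earlier steps also exchanged the group on the sulfonyl sulfur without yielding a readable number, so no sized step bears on this change. Compound 4 is therefore expected to remain beyond the range of this assay, with an estimate of 80000 nM between 30000 nM and 200000 nM, an expected step that the limit leaves unreadable from compound 3 to compound 4.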

Compound 4, half-maximal effective concentration: > 34400 nM
Compound 4 was reported as a limit; the forecaster's own chance of this, stated with the estimate: 85%; the middle value is on the limit's open side.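

Compound 4, like compound 1, compound 2 and compound 3, gives only a limit in this assay, so none of its steps to those compounds can be read. The compounds shown leave open whether any group on the sulfonyl sulfur would give a readable value in this assay.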